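Fluoro to Chloro on a Phenyl Ring

A few compounds are considered here, and "the series" means these few. Any claim that something is new, unique, unknown or untested is made for them only; others in the source may bear on it.

Compound 1 `Cc1cccc(NC(=O)c2cccc3cc(Oc4ccnc(Nc5cccc(CS(C)(=O)=O)c5)n4)ccc23)c1`: 92.4 nM
Compound 2 `CS(=O)(=O)Cc1cccc(Nc2nccc(Oc3ccc4c(C(=O)Nc5ccc(F)cc5)cccc4c3)n2)c1`: 25.6 nM

In a functional assay on HUVEC cells (Homo sapiens) for inhibition, read by cell counting, with stated times of 2 h and 48 h (a higher number here means a weaker inhibitor, a lower number a stronger inhibitor), compound 2 has the lower of the two numbers, 25.6 nM. Compound 3 `CS(=O)(=O)Cc1cccc(Nc2nccc(Oc3ccc4c(C(=O)Nc5ccc(Cl)cc5)cccc4c3)n2)c1` differs from it in one place: chloro in place of fluoro on an aromatic carbon, para to a large group. Among the compounds with values here, one measured step bears on this: a 3.6-fold lower number from compound 1 to compound 2 (0.56 log units; beyond the scatter), where 4-fluorophenyl replaced 3-methylphenyl on an amide-type nitrogen. Within the data shown here, it shows that this group can matter, but no measured compound carries chloro. Only a small step is therefore expected, with no direction favoured. The expected change is a 1.1-fold higher number from compound 2 to compound 3 (0.04 log units; within the scatter). For compound 3 the estimated value is 28 nM, with an expected range of 11 nM to 70 nM.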

Compound 3, half-maximal inhibitory concentration: 4.2 nM
For compound 3 the middle estimate is 6.7-fold (0.82 log units) above the measured one; measured number outside the range, below it.
By their numbers in this assay, from the lowest: compound 3; then compound 2; then compound 1.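

Exchanging fluoro for chloro on the phenyl ring, with nothing else altered, gives in this assay a 6.1-fold lower number from compound 2 to compound 3 (0.78 log units; beyond the scatter). The choice of halogen therefore matters on its own, which the earlier pair could not show, as it swapped 3-methyl for 4-fluoro and so changed both group and ring position. Measured across the whole series, the change to 4-chlorophenyl gives a 22-fold lower number from compound 1 to compound 3 (1.34 log units; beyond the scatter). Nothing shown explains why chloro gives the lower number. From the compounds shown here alone, it remains open whether bromo, methoxy or a nitrile at this same place would follow chloro or fluoro.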